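The source may hold more compounds than are shown below. What is called first, only, known or untested is meant among the compounds shown, and "the series" means these compounds.

Working notes on the series. Compound 1 `Cc1ccc(S(=O)(=O)N2CCC(N3CCC(C)CC3)CC2)cc1C` has been run in an ADME assay on HCT-116 cells (Homo sapiens) for cytotoxicity, read by CellTiter-Glo, with a stated time of 72 h (a lower number here means a stronger inhibitor, a higher number a weaker inhibitor), where compound 1 gives > 5000 nM, a limit of the measurement rather than a number. On the numbers to hand, compound 1 therefore stands only at a limit, with nothing to rank it against. Compound 2 `CC1CCN(C2CCN(S(=O)(=O)c3ccccc3-c3ccc(Cl)cc3)CC2)CC1` in this assay gives > 5000 nM, again a limit. Compound 3 `CC1CCN(C2CCN(S(=O)(=O)c3cccc(-c4ccccc4C(F)(F)F)c3)CC2)CC1` in this assay gives > 5000 nM, also a limit. Among the compounds with values here, what the three values together show is the limit of > 5000 nM in this assay, at which 3 of the 3 values shown sit; no difference between the three can be read, and no step between measured compounds is available.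

Compound 4 `CC1CCN(C2CCN(S(=O)(=O)c3cn(C)cn3)CC2)CC1` has not yet been measured in this assay. Against compound 1 it carries 1-methyl-1H-imidazol-4-yl in place of 3,4-dimethylphenyl on a sulfonyl sulfur. The change sits on the same sulfonyl sulfur that carries the aromatic group in each of the three measured compounds, and none of those three reached a number in this assay. With every measured member of the series at the limit, the expected step that the limit leaves unreadable from compound 1 to compound 4 is none beyond the scatter. Compound 4 is estimated in this assay at about 15000 nM, within a range from 4000 nM to 60000 nM, with a good chance that only a limit is reported once more.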

Compound 4, half-maximal inhibitory concentration: > 10000 nM
Compound 4 was reported as a limit (the forecaster's own chance of this, stated with the estimate: 85%); the middle value does not contradict the limit.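

Compound 1 and compound 4 are both reported only as limits in this assay, and the step between them cannot be read. The compounds shown leave open the concentration at which any of them reaches half-maximal inhibition in this assay, and whether 1-methyl-1H-imidazol-4-yl and 3,4-dimethylphenyl on the sulfonyl sulfur differ there at all.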